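The source may report more compounds than this note shows. Statements on the series, on what has been measured and on what is new or still open speak of the compounds shown alone.

Among the compounds with values here, in an ADME assay on Caco-2 cells (Homo sapiens) for permeability, read by LC-MS, in the apical to basolateral direction, with a stated time of 2 h (on this read-out higher numbers stand for higher permeability and lower numbers for lower permeability), compound 1 `COc1cc(C(=O)N2CCC(O)C(C)C2)cc2nc(NCc3cc(Cl)ccn3)oc12` gives 41 nm/s, the only number available in this small series. Within the data shown here, for compound 2 `COc1cc(C(=O)N2CCC(O)C(C)C2)cc2nc(N[C@@H](C)c3cccc(Cl)c3)oc12` the entry reads "not determined" (no result reported), so compound 1 cannot be ranked against it and no measured step exists to calibrate a structural change. Compound 3 `COc1cc(C(=O)N2CC(C)OCC2CCO)cc2nc(NCc3cc(Cl)ccn3)oc12` keeps the shared core and the amine side of compound 1 but alters the amide: 5-(2-hydroxyethyl)-2-methylmorpholin-4-yl in place of 4-hydroxy-3-methylpiperidin-1-yl on a carbonyl carbon. In words, 5-(2-hydroxyethyl)-2-methylmorpholin-4-yl stands in place of 4-hydroxy-3-methylpiperidin-1-yl on a carbonyl carbon. Among the measured compounds shown here, with no measured precedent for this swap, the expectation stays anchored on compound 1 at 41 nm/s and is deliberately wide. The expected step in this assay is a 1.3-fold lower number from compound 1 to compound 3 (0.11 log units; within the scatter), and no change beyond the usual scatter is expected. For compound 3 the estimated value is 32 nm/s, with an expected range of 12 nm/s to 80 nm/s.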

Compound 3, apparent permeability: 111 nm/s
The estimate for compound 3 lay 3.5-fold (0.54 log units) below the measured number, outside the stated range (above it).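

On a carbonyl carbon whose other neighbours are aromatic carbon, the choice of amide group moves the read-out: in this assay, 5-(2-hydroxyethyl)-2-methylmorpholin-4-yl in place of 4-hydroxy-3-methylpiperidin-1-yl gives a 2.7-fold higher number from compound 1 to compound 3 (0.43 log units; beyond the scatter). This first measured step in the series shows that, for this one pair, a group with more heavy atoms and more hydrogen-bond acceptors, the same hydrogen-bond donor count and no net charge can carry a higher number than the group it replaces. No available measurement bears on the reason for the step.

This single pair does not separate the ring oxygen from the 2-hydroxyethyl chain, so a plain morpholin-4-yl or a 2-methylmorpholin-4-yl would be needed to tell the two apart. As far as these compounds go, whether the step holds with a different amine side on the shared core also stays open.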